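The source may hold more compounds than are shown below. What is called first, only, known or untested is meant among the compounds shown, and "the series" means these compounds.

Compound 1 `CC1=C(C(=O)OC(C)(C)C)C(c2ccsc2)NC(=O)N1`, in an assay on membranes from CHO cells for displacement of a labelled ligand from adenosine receptor A1 (Homo sapiens), read by scintillation counting, with a stated time of 60 min, tested at 1 uM (on this read-out higher numbers stand for more inhibition at the one concentration tested (going by the name of the read-out) and lower numbers for less inhibition), gives 15%; compound 2 `CC1=C(C(=O)OCc2ccccc2)C(c2ccsc2)NC(=O)N1` gives 57%; compound 3 `CC1=C(C(=O)OC(C)(C)C)C(c2ccsc2)NC(=O)N1C` gives 18%.

Among these three, compound 1 stands lowest. Its nearest neighbour is compound 3, reached by methyl in place of hydrogen on an amide-type nitrogen in a ring, a step of a number 3 percentage points higher from compound 1 to compound 3 (within the scatter). The furthest is compound 2, reached by benzyl in place of tert-butyl on an oxygen next to a carbonyl group, a step of a number 42 percentage points higher from compound 1 to compound 2 (beyond the scatter).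

Compound 4 `CC(=O)C1=C(C)NC(=O)NC1c1ccsc1` differs from compound 1 by methyl in place of tert-butoxy on a carbonyl carbon. For the measured compounds named here, only the step to compound 2 touches the same carbonyl carbon, and it was large; the step to compound 3 concerns a different site and was within the scatter. Going by the values given here, no measured pair replaces tert-butoxy with methyl, so the direction is not settled by the data, though the large step to compound 2 shows that change at this carbonyl carbon can move the read-out considerably.

Compound 4 is therefore expected to give about 22%, within 5% to 45%, an expected step of a number 7 percentage points higher from compound 1 to compound 4 (within the scatter).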

Compound 4, a percentage reported as inhibition, at one concentration (the size of the read-out at that concentration, not a potency): 9%
The estimate for compound 4 lay 13 percentage points above the measured number; the measured number falls inside the stated range.
By their numbers in this assay, from the lowest: compounds 4, 1 and 3 (each within the scatter of the next); then compound 2.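

In this assay, methyl in place of tert-butoxy on a carbonyl carbon gives a number 6 percentage points lower from compound 1 to compound 4 (within the scatter). The earlier compounds shown here showed only that this carbonyl carbon can carry a large change, through a number 42 percentage points higher from compound 1 to compound 2 (beyond the scatter); this result adds that removing the whole tert-butoxy group, oxygen included, need not move the read-out, so not every change here has a large effect. No measurement is available that would explain either step.

The compounds shown leave open whether an ethoxy or a cyclohexylmethoxy group on the same carbonyl carbon would give a number close to that of compound 1 or close to that of compound 2. They also leave open whether an amine at that place, which would turn the carbonyl group into an amide, would behave like methyl or like benzyloxy.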